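This account rests on a few compounds, and the source may have more. Where it says the series, first, only, none or still open, it means among the compounds named here.

Working notes on the series. Compound 1 `CC(O)CSc1nc(NCc2ccc(-c3ccccn3)cc2)c2[nH]nc(C(C)C)c2n1` is the reference point; in a functional assay on HT cells (Homo sapiens) for antiproliferative activity, read by fluorescence, with a stated time of 72 h (a higher number here means a weaker inhibitor of growth, a lower number a stronger inhibitor of growth), compound 1 gives 62 nM. Two analogues alter the same position. Compound 2 `CC(C)c1n[nH]c2c(NCc3ccc(-c4ccccn4)cc3)nc(SCCC(N)=O)nc12` gives 120 nM, and compound 3 `CC(C)c1n[nH]c2c(NCc3ccc(-c4ccccn4)cc3)nc(SCCNC(N)=O)nc12` gives 240 nM. Among the three numbers compound 1 stands at the low end: the step of a 1.9-fold higher number from compound 1 to compound 2 (0.29 log units; within the scatter) is within the scatter, while a 3.9-fold higher number from compound 1 to compound 3 (0.59 log units; beyond the scatter) is beyond it, and a 2.0-fold higher number from compound 2 to compound 3 (0.30 log units; within the scatter) is within the scatter.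

Compound 4 `CNCCSc1nc(NCc2ccc(-c3ccccn3)cc2)c2[nH]nc(C(C)C)c2n1` is not yet measured. Its difference from compound 1: (methylamino)methyl in place of 1-hydroxyethyl on a saturated chain carbon bound to a sulfur

The two measured steps from compound 1, to compound 2 and to compound 3, both replace the 1-hydroxyethyl at this same place, and both read higher, one within the scatter and one modestly beyond. Within the data shown here, no step with a (methylamino)methyl group exists, so the direction can only be taken from these. A small upward step or none beyond the scatter is expected for compound 4, that is a 1.6-fold higher number from compound 1 to compound 4 (0.21 log units; within the scatter). In this assay compound 4 is therefore estimated at 100 nM, with a range from 40 nM to 260 nM.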

Compound 4, concentration for 50% growth inhibition: 56 nM
For compound 4 the middle estimate is 1.8-fold (0.25 log units) above the measured one; measured number inside the range.
By their numbers in this assay, from the lowest: compounds 4, 1, 2 and 3 (each within the scatter of the next, the first and the last beyond it).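

At this place, on a saturated chain carbon bound to a sulfur, the 1-hydroxyethyl of compound 1 can give way to (methylamino)methyl with no reading beyond the scatter in this assay: a 1.1-fold lower number from compound 1 to compound 4 (0.04 log units; within the scatter). The chain carrying the nitrogen thus holds the number of the reference without any hydroxyl or carbonyl, and the two carbonyl-bearing analogues now separate from it: a 4.3-fold lower number from compound 3 to compound 4 (0.63 log units; beyond the scatter), and a 2.1-fold lower number from compound 2 to compound 4 (0.33 log units; beyond the scatter). Among these compounds, on the amine nitrogen, the methyl of compound 4 and the carbamoyl of compound 3 therefore give a modest difference, the only step here that turns on that nitrogen's substituent.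

The compounds shown leave open how a primary amine, a dimethylamino group, a carboxylic acid or a longer chain would read at this place. What lies behind these differences also stays open, as no measurement bearing on it is available.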